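The source may report more compounds than this note shows. Statements on the series, on what has been measured and on what is new or still open speak of the compounds shown alone.

Compound 2 `COc1cc(OC)c2c(-n3ccnc3)cc(-c3ccccc3)nc2c1` gives 58600 nM in a functional assay on HepG2 cells (Homo sapiens) for inhibition, read by MTT assay, with a stated time of 72 h (a lower number here means a stronger inhibitor, a higher number a weaker inhibitor), the higher of the two numbers recorded; compound 1 `CCCNc1cc(-c2ccccc2)nc2cc(OC)cc(OC)c12` gives 5210 nM. Among the compounds with values here, the one measured step, an 11-fold higher number from compound 1 to compound 2 (1.05 log units; beyond the scatter), joins those two. Compound 3 `COc1cc(OC)c2c(NC3CCCCC3)cc(-c3ccccc3)nc2c1` differs from compound 2 by cyclohexylamino in place of 1H-imidazol-1-yl on an aromatic carbon. That change reverses the replacement of propylamino by 1H-imidazol-1-yl seen in the measured step, with a different amino group entering, so a step back in the lowering direction is expected, of a size near the measured one. Compound 3 is therefore expected to reach 6000 nM, between 1500 nM and 25000 nM. The expected step is a 9.8-fold lower number from compound 2 to compound 3 (0.99 log units; beyond the scatter).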

Compound 3, half-maximal inhibitory concentration: 3160 nM
The estimate for compound 3 lay 1.9-fold (0.28 log units) above the measured number; the measured number falls inside the stated range.
By their numbers in this assay, from the lowest: compounds 3 and 1 (each within the scatter of the next); then compound 2.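

In this assay, cyclohexylamino in place of 1H-imidazol-1-yl gives a large step (a 19-fold lower number from compound 2 to compound 3 (1.27 log units; beyond the scatter)), so two different amino groups now stand well clear of compound 2, and the effect is not confined to propylamino. Cyclohexyl in place of propyl on that nitrogen stays within the scatter (a 1.6-fold lower number from compound 1 to compound 3 (0.22 log units; within the scatter)), so a ring of carbon and an open chain serve alike here. Nothing shown explains these differences. As far as these compounds go, what a dimethylamino group, with no hydrogen on the nitrogen, or an anilino group would give at this position stays open.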